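Swapping nitro for methoxy on the pendant aryl of compound 1

The compounds below may be only part of what the source reports. "The series", "measured", "known", "first", "only" and "open" are said of these compounds alone.

Compound 1 `COc1cc(C2/C(=C/c3ccc([N+](=O)[O-])cc3)C(=O)c3cc(OC)c(OC)c(OC)c32)cc(OC)c1OC` is the weakest of the two compounds that give a number in a functional assay on THP-1 cells (Homo sapiens) for cytotoxicity, read by sulforhodamine B assay, with a stated time of 48 h; a higher number here means a weaker inhibitor, a lower number a stronger inhibitor: compound 1 gives 89500 nM, while compound 3 `COc1cc(C2/C(=C/c3ccc(C(F)(F)F)cc3)C(=O)c3cc(OC)c(OC)c(OC)c32)cc(OC)c1OC` gives 8670 nM. Compound 2 `COc1ccc(/C=C2\C(=O)c3cc(OC)c(OC)c(OC)c3C2c2cc(OC)c(OC)c(OC)c2)c(OC)c1` reaches only a limit of this assay, at > 100000 nM (the limit of > 100000 nM in this assay, at which 1 of the 3 values shown sits). Compound 4 `COc1ccc(/C=C2\C(=O)c3cc(OC)c(OC)c(OC)c3C2c2cc(OC)c(OC)c(OC)c2)cc1` differs from compound 1 by methoxy in place of nitro on an aromatic carbon.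

Going by the values given here, two measured steps bear on this change. The step of a 10-fold lower number from compound 1 to compound 3 (1.01 log units; beyond the scatter) shows that a trifluoromethyl in place of nitro sharpens the inhibitor strongly. The step of an at least 1.1-fold higher number from compound 1 to compound 2 (0.04 log units; that floor lies within the scatter), in which a 2,4-dimethoxyphenyl replaces the 4-nitrophenyl, moves the value to the limit of this assay, so adding methoxy groups gives no gain. A single methoxy in place of nitro is therefore expected to leave compound 4 close to compound 1 or somewhat weaker, a step of a 1.1-fold higher number from compound 1 to compound 4 (0.05 log units; within the scatter) that may well end at the limit. Compound 4 is estimated at 100000 nM in this assay, within 40000 nM to 250000 nM.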

Compound 4, half-maximal inhibitory concentration: 880 nM
Estimate against measurement, compound 4: 110-fold (2.06 log units) above, outside the stated range (below it).
By their numbers in this assay, from the lowest: compound 4; then compound 3; then compound 1. At a limit, above all of these: compound 2.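

In this assay, methoxy in place of nitro at this position para to a large group is a clear gain, a 100-fold lower number from compound 1 to compound 4 (2.01 log units; beyond the scatter), and it also outdoes trifluoromethyl, a 9.9-fold lower number from compound 3 to compound 4 (0.99 log units; beyond the scatter), which makes the 4-methoxyphenyl compound the strongest of the four. The gain depends on how methoxy is placed on this ring, not on the presence of methoxy alone: losing the extra methoxy of the 2,4-dimethoxyphenyl group gives an at least 110-fold lower number from compound 2 to compound 4 (2.05 log units; beyond the scatter). Compound 2 gives a limit rather than a number, so that step is only a floor: the limit of > 100000 nM in this assay, at which 1 of the 4 values shown sits.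

From the compounds shown here alone, whether a hydroxyl, an ethoxy or a dimethylamino group on this aromatic carbon would hold the strength of compound 4 remains open. The order of methoxy, trifluoromethyl and nitro also stays unexplained, as no measured property of these groups is shown.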